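This account rests on a few compounds, and the source may have more. Where it says the series, first, only, none or still open, it means among the compounds named here.

Measured compounds:
compound 1, `C=C(F)C(=O)Nc1cc(Nc2nccc(-c3cn(C)c4ccccc34)n2)c(OC)cc1N(C)CCN(C)C`, 3790 nM
compound 2, `C=C(Cl)C(=O)Nc1cc(Nc2nccc(-c3cn(C)c4ccccc34)n2)c(OC)cc1N(C)CCN(C)C`, 1390 nM
compound 3, `COc1cc(N(C)CCN(C)C)c(NC(=O)C=C(C)C)cc1Nc1nccc(-c2cn(C)c3ccccc23)n1`, 5660 nM

All three share one core and differ only in the group carried on the amide carbonyl carbon. In a functional assay on HepG2 cells (Homo sapiens) for antiproliferative activity, read by MTT assay, with a stated time of 72 h (a higher number here means a weaker inhibitor, a lower number a stronger inhibitor), compound 1 stands second highest of the three numbers, with compound 3 nearest and compound 2 furthest from it. The step of a 2.7-fold lower number from compound 1 to compound 2 (0.44 log units; beyond the scatter) lies beyond the scatter, whereas a 1.5-fold higher number from compound 1 to compound 3 (0.17 log units; within the scatter) lies within it; the step of a 4.1-fold higher number from compound 2 to compound 3 (0.61 log units; beyond the scatter) is again beyond the scatter.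

Compound 4, `CCC/C=C\C(=O)Nc1cc(Nc2nccc(-c3cn(C)c4ccccc34)n2)c(OC)cc1N(C)CCN(C)C`, is not yet measured. Its difference from compound 1 is pent-1-en-1-yl in place of 1-fluoroethenyl on a carbonyl carbon. The closest guide is the step from compound 1 to compound 3, which also removes the 1-fluoroethenyl group and puts in its place a carbon substituent with no halogen; that step, a 1.5-fold higher number from compound 1 to compound 3 (0.17 log units; within the scatter), stayed within the scatter. The chloro step a 2.7-fold lower number from compound 1 to compound 2 (0.44 log units; beyond the scatter) went the other way but does not concern a halogen-free group. Compound 4 is therefore expected to move little from compound 1 in this assay, with the step estimated as a 1.3-fold higher number from compound 1 to compound 4 (0.12 log units; within the scatter). The value of compound 4 is estimated at 5000 nM, within a range from 2000 nM to 12500 nM.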

Compound 4, half-maximal inhibitory concentration: 431 nM
Beside the measured number, compound 4's estimate is 12-fold (1.06 log units) above it, and the stated range ends above it.
By their numbers in this assay, from the lowest: compound 4; then compound 2; then compounds 1 and 3 (each within the scatter of the next).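

In this assay the halogen-free pent-1-en-1-yl group on the carbonyl carbon gives the lowest number of the four compounds, and it does so beyond the scatter against each of the others (an 8.8-fold lower number from compound 1 to compound 4 (0.94 log units; beyond the scatter)) (a 3.2-fold lower number from compound 2 to compound 4 (0.51 log units; beyond the scatter)) (a 13-fold lower number from compound 3 to compound 4 (1.12 log units; beyond the scatter)). This shows that a halogen on this group is not required for the lowest number among these compounds, as compound 4 carries none and still stands below the chloro compound 2. It also shows that this position can respond strongly to a change between two halogen-free groups, since 2-methylprop-1-en-1-yl in compound 3 and pent-1-en-1-yl in compound 4 lie far apart, although both carry a carbon substituent with one double bond. No evidence is available to explain this difference.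

The compounds shown leave open whether the gain would persist with a longer chain such as hept-1-en-1-yl, or with a saturated pentyl group in place of pent-1-en-1-yl. They also leave open whether a chain ending in a dimethylamino group would fit at this position.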